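Benzoyl in Place of Methoxy: What to Expect

The source may hold more compounds than are shown below. What is called first, only, known or untested is meant among the compounds shown, and "the series" means these compounds.

Three compounds have been measured in a functional assay on HL-60 cells (Homo sapiens) for inhibition, read by MTT assay, with a stated time of 72 h, tested at 50 uM; on this read-out lower numbers stand for less inhibition of growth and higher numbers for more inhibition of growth at the one concentration tested:

Compound 1 `C=CCc1ccc(OCc2cn(-c3ccc(C#N)cc3)nn2)c(O)c1` gives 31.8%.
Compound 2 `C=CCc1ccc(OCc2cn(-c3ccc(OC)cc3)nn2)c(O)c1` gives 38.9%.
Compound 3 `C=CCc1ccc(OCc2cn(-c3cccc(C#N)c3)nn2)c(O)c1` gives 30.9%.

All three share one core and differ only in the group on the ring attached to the aromatic nitrogen. Compound 2 carries the highest of the three numbers, yet this tells little: the step of a number 7.1 percentage points higher from compound 1 to compound 2 (within the scatter) and the step of a number 8 percentage points lower from compound 2 to compound 3 (within the scatter) both stay within the scatter, as does the step of a number 0.9 percentage points lower from compound 1 to compound 3 (within the scatter). On these numbers the three compounds cannot be told apart.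

Compound 4 `C=CCc1ccc(OCc2cn(-c3ccc(C(=O)c4ccccc4)cc3)nn2)c(O)c1` has not yet been measured. It differs from compound 2 in one place: benzoyl in place of methoxy on an aromatic carbon. Going by the values given here, the only measured step that touches the same place is the step from compound 1 to compound 2, where a cyano gave way to the methoxy without a shift beyond the scatter. Among the compounds with values here, no measured step tests a benzoyl, so there is nothing to suggest a larger move.

Compound 4 is therefore expected to show a number 0.9 percentage points lower from compound 2 to compound 4 (within the scatter), in effect no step beyond the scatter. The estimate for compound 4 in this assay is 38%, expected to fall between 20% and 56%.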

Compound 4, percent growth inhibition at one concentration: 40.5%
For compound 4 the middle estimate is 2.5 percentage points below the measured one, within the range that was stated.
By their numbers in this assay, from the lowest: compounds 3, 1, 2 and 4 (each within the scatter of the next).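

In this assay, the group on this ring can go from methoxy, with 2 heavy atoms and no ring, to benzoyl, with 8 heavy atoms and a six-membered aromatic ring of carbon only, and the result is a number 1.6 percentage points higher from compound 2 to compound 4 (within the scatter). Going by these compounds alone, the comparison with the cyano group tells the same story, with a number 8.7 percentage points higher from compound 1 to compound 4 (within the scatter), so even this much larger group, which the earlier compounds did not test, gives no shift beyond the scatter at this aromatic carbon, para to a large group. No measurement at hand offers an explanation for this lack of separation.

On these data alone, it remains open whether an amine, a carboxylic acid or a longer alkyl chain at this same aromatic carbon would move the number beyond the scatter. Also open, as far as these compounds go, is whether compounds that cannot be told apart at the one concentration tested would separate if full concentration-response curves were recorded.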